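A few compounds are considered here, and "the series" means these few. Any claim that something is new, unique, unknown or untested is made for them only; others in the source may bear on it.

Measured compounds in a functional assay on NCI-H1975 cells (Homo sapiens) for inhibition, read by sulforhodamine B assay, tested at 10 uM; a lower number here means less inhibition, a higher number more inhibition at the concentration tested (going by the name of the read-out):

compound 1 `CN(C)c1ccc(C2CC(c3ccc(-n4cncn4)cc3)=NN2S(=O)(=O)c2ccc(C(F)(F)F)cc2)cc1`: 5.5%
compound 2 `CN(C)c1ccc(C2CC(c3ccc(-n4cncn4)cc3)=NN2S(=O)(=O)c2ccc(C#N)cc2)cc1`: 22.6%
compound 3 `CN(C)c1ccc(C2CC(c3ccc(-n4cncn4)cc3)=NN2S(=O)(=O)c2ccc(OC(F)(F)F)cc2)cc1`: 11.1%

All three share one core and differ only in the group on the sulfonyl-bearing aromatic ring. Compound 2 gives the highest of the three numbers in this assay ; the nearest is compound 3, reached by a number 11.5 percentage points lower from compound 2 to compound 3 (beyond the scatter), and the furthest is compound 1, reached by a number 17.1 percentage points higher from compound 1 to compound 2 (beyond the scatter). The remaining step, a number 5.6 percentage points higher from compound 1 to compound 3 (within the scatter), is within the scatter.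

Compound 4 `CN(C)c1ccc(C2CC(c3ccc(-n4ccnc4)cc3)=NN2S(=O)(=O)c2ccc(C#N)cc2)cc1` is not yet measured. It differs from compound 2 by 1H-imidazol-1-yl in place of 1H-1,2,4-triazol-1-yl on an aromatic carbon. Among the compounds with values here, none of the measured steps touches this part of the molecule: every step so far exchanges the substituent on the sulfonyl aryl ring, so there is no measured precedent for the exchange of the five-membered ring on the other aryl group. The size of the effect therefore cannot be read from the series, and an expectation has to rest on compound 2 alone.

Within the data shown here, with no precedent, a step within the scatter is expected, a number 2.6 percentage points lower from compound 2 to compound 4 (within the scatter). Compound 4 is estimated at 20% in this assay, with a range from 5% to 38%.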

Compound 4, a percentage reported as inhibition, at one concentration (the size of the read-out at that concentration, not a potency): 0.7%
The estimate for compound 4 lay 19.3 percentage points above the measured number; the measured number lies below the stated range.
By their numbers in this assay, from the lowest: compounds 4, 1 and 3 (each within the scatter of the next, the first and the last beyond it); then compound 2.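

Within the data shown here, the series had so far varied only the substituent on the sulfonyl-bearing aromatic ring, and the first exchange at the five-membered ring on the other aryl group is not silent in this assay: it gives a number 21.9 percentage points lower from compound 2 to compound 4 (beyond the scatter). Both rings are five-membered aromatic rings with 0 hydrogen-bond donors, sitting on an aromatic carbon para to a large group, and they differ only in 3 against 2 hetero atoms and 3 against 2 hydrogen-bond acceptors, so the read-out responds to a small exchange at this position and the 1H-1,2,4-triazol-1-yl form is the one that holds the higher number with the nitrile in place. Nothing shown here accounts for the step.

From the compounds shown here alone, the 1H-imidazol-1-yl ring appears only with the nitrile, so it remains open whether the same step would be seen with trifluoromethyl or trifluoromethoxy on the sulfonyl-bearing ring. Also open, going by these compounds, is how other groups would read at this position, such as a 1H-tetrazol-1-yl ring, a pyridine ring, or a simple amine or carboxylic acid in place of the five-membered ring.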